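The source may report more compounds than this note shows. Statements on the series, on what has been measured and on what is new or still open speak of the compounds shown alone.

Two compounds of the series have numbers in an ADME assay on BaF3 cells (Mus musculus) for inhibition, read by CellTiter-Glo, with a stated time of 72 h; a lower number here means a stronger inhibitor of growth, a higher number a weaker inhibitor of growth. Compound 1 `CCN1CCN(c2ccc(Nc3ncc4c(n3)N(C)C(=O)N(c3cc(NC(=O)c5cccc(C(F)(F)F)c5)ccc3C)C4)cc2)CC1` gives in this assay 559 nM. Compound 2 `Cc1ccc(Nc2ncc3c(n2)N(C)C(=O)N(c2cc(NC(=O)c4ccc(-n5cccc5)c(C(F)(F)F)c4)ccc2C)C3)cn1` gives in this assay 317 nM; this is the lowest of the two numbers, and the nearest, compound 1, lies within the scatter of it, so the two cannot be put in order. Going by the values given here, no step between measured compounds that differ in one place is available in this set. Compound 3 `Cc1ccc(Nc2ncc3c(n2)N(C)C(=O)N(c2cc(NC(=O)c4ccc(C)c(C(F)(F)F)c4)ccc2C)C3)cn1` is the next compound for this assay. Relative to compound 2 the change is methyl in place of 1H-pyrrol-1-yl on an aromatic carbon. Among the compounds with values here, with no measured step for such a change, the expectation in this assay is a small shift toward a higher number, if any, not beyond the scatter: the expected step is a 1.3-fold higher number from compound 2 to compound 3 (0.12 log units; within the scatter). Compound 3 is estimated in this assay at 420 nM, with a range from 150 nM to 1200 nM.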

Compound 3, concentration for 50% growth inhibition: 870 nM
For compound 3 the middle estimate is 2.1-fold (0.32 log units) below the measured one, and the stated range covers the measured number.
By their numbers in this assay, from the lowest: compounds 2, 1 and 3 (each within the scatter of the next, the first and the last beyond it).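

In this assay, going by these compounds alone, the replacement of 1H-pyrrol-1-yl by methyl gives a 2.7-fold higher number from compound 2 to compound 3 (0.44 log units; beyond the scatter) and is the first step at a single place, on the aromatic carbon ortho to a trifluoromethyl group and para to a large group. This position therefore responds to what it carries, and here the five-membered aromatic ring goes with the lower number, although that reading rests on one pair and a modest step. No measurement at hand accounts for the step.

Going by these compounds, it remains open whether the lower number of compound 2 goes with an aromatic ring as such or simply with more heavy atoms at this carbon. A phenyl ring, a longer alkyl chain or a morpholine at the same place would separate these two readings.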